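The source may report more compounds than this note shows. Statements on the series, on what has been measured and on what is new or still open speak of the compounds shown alone.

Three compounds have been measured in an assay on cells (Oocyte) for inhibition of pannexin-1 (Mus musculus), read by voltage clamp, tested at 50 uM, in the presence of a further agent that is not named here; a lower number here means less inhibition, a higher number more inhibition at the concentration tested (going by the name of the read-out):
compound 1, `O=C(O)c1ccc(CNS(=O)(=O)c2ccc3c(c2)cc(C(=O)O)n3Cc2ccc(C(=O)O)cc2)cc1`, 100%;
compound 2, `O=C(O)c1ccc(Cn2cc(C(=O)O)c3cc([N+](=O)[O-])ccc32)cc1`, 54%;
compound 3, `O=C(O)c1cn(CCCc2ccccc2)c2ccc([N+](=O)[O-])cc12`, 71%.

Compound 1 stands highest of the three. Its nearest neighbour is compound 3, whose number is lower by an amount beyond the usual scatter of repeated measurements, and compound 2 lies lower still, also beyond the scatter. No two of these compounds differ in only one place, so none of the gaps between them can be tied to a single structural change; they show only that different groups on the shared core give different degrees of inhibition.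

Compound 4, `O=C(O)c1ccc(CN(Cc2ccc(C(=O)O)cc2)S(=O)(=O)c2ccc3c(c2)cc(C(=O)O)n3Cc2ccc(C(=O)O)cc2)cc1`, has not yet been measured in this assay. It differs from compound 1 in one place: 4-carboxybenzyl in place of hydrogen on a sulfonamide nitrogen. The sulfonamide nitrogen thus carries a second 4-carboxybenzyl where compound 1 had a hydrogen.

Because compound 1 already gives 100%, there is no room above it, and the step can only be flat or downward. Going by the values given here, with no measured single-point step to lean on, the expected step from compound 1 to compound 4 is a number 15 percentage points lower from compound 1 to compound 4 (beyond the scatter), a modest decrease that may well sit within the scatter. Compound 4 is therefore expected to give 85%, with a likely range from 55% to 100%.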

Compound 4, a percentage reported as inhibition, at one concentration (the size of the read-out at that concentration, not a potency): 79%
For compound 4 the middle estimate is 6 percentage points above the measured one; the range from low to high includes it.
By their numbers in this assay, from the lowest: compound 2; then compounds 3 and 4 (each within the scatter of the next); then compound 1.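

Going by these compounds alone, this is the first step in the set that can be tied to a single change: in this assay, 4-carboxybenzyl in place of hydrogen on a sulfonamide nitrogen gives a number 21 percentage points lower from compound 1 to compound 4 (beyond the scatter). The hydrogen on this nitrogen is therefore not essential for inhibition, since compound 4, which carries this added group there, still gives 79%, although the step shows that the change does cost some inhibition at the concentration tested. Nothing measured here explains the size of this step.

The compounds shown leave open which part of the added group matters, the six-membered aromatic ring or its carboxylic acid, and a plain benzyl, a methyl or a longer chain ending in a carboxylic acid on the same nitrogen would help to separate the two. They also leave open how the two compounds compare in potency, as a single percentage at one concentration is not a potency.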